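Dropping the iodine from a pyridyl diazepane nicotinic agonist

The source may report more compounds than this note shows. Statements on the series, on what has been measured and on what is new or still open speak of the compounds shown alone.

Of the compounds shown here, three have so far been measured in a functional assay on HEK293 cells for agonist activity at Neuronal acetylcholine receptor; alpha4/beta2 (Homo sapiens), read by FLIPR and calcium flux; a lower number here means that less compound is needed, a higher number that more compound is needed for the effect. Compound 1 `COc1cc(N2CCNCC2)cnc1Br` gives 17000 nM, the highest number of the three. Compound 3 `COc1cncc(N2CCCNCCC2)c1` gives 120 nM, the lowest. Compound 2 `Oc1cc(N2CCCNCC2)cnc1I` gives 479 nM, which places it second highest of the three numbers: its nearest neighbour is compound 3, whose lower number lies beyond the usual scatter, and compound 1 lies far higher, also well beyond the scatter.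

Compound 4 `Oc1cncc(N2CCCNCC2)c1` is the next compound to be measured in this assay. It differs from compound 2 in a single place, hydrogen in place of iodo on an aromatic carbon. Among the compounds with values here, no two of the measured compounds differ in only one place, so no measured step shows what removing this halogen does here; compounds 1 and 3 each differ from compound 2 in more than one place at once, and their numbers cannot be traced to the halogen alone.

Within the data shown here, with no direct precedent, a modest loss of activity is expected, a step from compound 2 to compound 4 of a 1.9-fold higher number from compound 2 to compound 4 (0.27 log units; within the scatter) in this assay. Compound 4 is therefore estimated at 900 nM, with a range from 200 nM to 4000 nM.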

Compound 4, half-maximal effective concentration: 141 nM
Estimate against measurement, compound 4: 6.4-fold (0.81 log units) above, and the stated range ends above it.
By their numbers in this assay, from the lowest: compounds 3 and 4 (each within the scatter of the next); then compound 2; then compound 1.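

The iodo group, on the aromatic carbon next to the ring nitrogen, is not needed for activity in this assay: putting hydrogen in its place gives a 3.4-fold lower number from compound 2 to compound 4 (0.53 log units; beyond the scatter). Within the data shown here, this is the first comparison in the set that changes one place only, so it isolates this halogen in a way compounds 1 and 3 could not, and it shows that less compound is needed without the iodine than with it. No measurement at hand bears on why the number falls, so the step stands as an observation without an explanation.

The compounds shown compare only iodo and hydrogen at this position, so a fluoro, a chloro or a methyl group there would be needed to tell whether the gain comes from losing iodine in particular or from having no group at all. The result also rests on a single pair carrying a hydroxy group, which leaves open whether removing a halogen from this position would act the same way alongside the methoxy group of compound 1.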